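The source may report more compounds than this note shows. Statements on the series, on what has been measured and on what is new or still open speak of the compounds shown alone.

Measured compounds:
Compound 1 `CCCCCCCCN1NN=C(NC(=O)Nc2c(C(C)C)cccc2C(C)C)N1` gives 59 nM in an assay on microsomes from intestine for inhibition of acyl-CoA:cholesterol acyltransferase (Oryctolagus cuniculus); on this read-out lower numbers stand for stronger inhibition and higher numbers for weaker inhibition.
Compound 2 `CCCCCCCCCCCN1NN=C(NC(=O)Nc2c(C(C)C)cccc2C(C)C)N1` gives 9 nM in this assay.

Going by the values given here, compound 2 stands lowest of the two numbers; its only neighbour is compound 1, reached by the step of a 6.6-fold lower number from compound 1 to compound 2 (0.82 log units; beyond the scatter). Compound 3 `CCCCCCCCCCCCCCN1NN=C(NC(=O)Nc2c(C(C)C)cccc2C(C)C)N1` has not yet been measured. It differs from compound 2 by propyl in place of hydrogen on a saturated chain carbon, ten or more bonds along the chain from an amine nitrogen in a ring. Among the compounds with values here, the one step of the same kind, a 6.6-fold lower number from compound 1 to compound 2 (0.82 log units; beyond the scatter), lowered the number. A lower number is therefore expected again, possibly smaller in size. Compound 3 is estimated at 5 nM, within 1.5 nM to 20 nM. The expected step is a 1.8-fold lower number from compound 2 to compound 3 (0.26 log units; within the scatter).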

Compound 3, half-maximal inhibitory concentration: 12 nM
For compound 3 the middle estimate is 2.4-fold (0.38 log units) below the measured one; measured number inside the range.
By their numbers in this assay, from the lowest: compounds 2 and 3 (each within the scatter of the next); then compound 1.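

Adding propyl at this far point of the chain gives a 1.3-fold higher number from compound 2 to compound 3 (0.12 log units; within the scatter) in this assay, so the gain from the earlier lengthening does not carry on here, and compound 2 and compound 3 cannot be told apart. The longer chain still keeps its advantage, with a 4.9-fold lower number from compound 1 to compound 3 (0.69 log units; beyond the scatter). No supporting data bear on why the trend stops.

As far as these compounds go, whether a still longer chain would hold this level or lose it remains open. So does whether a chain ending in a carboxylic acid or an amine would fit this position equally well.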